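Aniline variation on the shared core: compound 4

A few compounds are considered here, and "the series" means these few. Any claim that something is new, unique, unknown or untested is made for them only; others in the source may bear on it.

Compound 3 `CCS(=O)(=O)Nc1cc(-c2ccc3ncnc(Nc4ccc(OC)c(OC)c4)c3c2)cnc1OC` gives 5820 nM in a functional assay on A549 cells (Homo sapiens) for cytotoxicity, read by sulforhodamine B assay, with a stated time of 72 h (on this read-out lower numbers stand for stronger inhibition and higher numbers for weaker inhibition), the lowest of the three numbers shown, though all three lie within the scatter of one another: compound 2 `CCS(=O)(=O)Nc1cc(-c2ccc3ncnc(Nc4ccc(F)cc4)c3c2)cnc1OC` gives 7620 nM and compound 1 `CCS(=O)(=O)Nc1cc(-c2ccc3ncnc(Nc4cccc(F)c4)c3c2)cnc1OC` gives 9940 nM, with steps of a 1.3-fold lower number from compound 1 to compound 2 (0.12 log units; within the scatter), a 1.7-fold lower number from compound 1 to compound 3 (0.23 log units; within the scatter) and a 1.3-fold lower number from compound 2 to compound 3 (0.12 log units; within the scatter). Compound 4 `CCS(=O)(=O)Nc1cc(-c2ccc3ncnc(Nc4ccc(F)c(C(=O)OC)c4)c3c2)cnc1OC` carries the change (4-fluoro-3-(methoxycarbonyl)phenyl in place of 3,4-dimethoxyphenyl on a nitrogen on an aromatic ring). Within the data shown here, no measured step covers this incoming group; the three earlier swaps of the same aryl group all stayed within the scatter, so a fourth swap at that place is expected to leave the number near that of compound 3. For compound 4 the expected step is a 1.1-fold higher number from compound 3 to compound 4 (0.05 log units; within the scatter), no direction beyond the scatter. Compound 4 is estimated at 6500 nM in this assay, with a range of 2500 nM to 17000 nM.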

Compound 4, half-maximal inhibitory concentration: 3420 nM
Estimate against measurement, compound 4: 1.9-fold (0.28 log units) above; measured number inside the range.
By their numbers in this assay, from the lowest: compounds 4, 3, 2 and 1 (each within the scatter of the next, the first and the last beyond it).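

In this assay the place on the nitrogen now gives steps beyond the scatter: methoxycarbonyl in place of hydrogen on an aromatic carbon gives (a 2.2-fold lower number from compound 2 to compound 4 (0.35 log units; beyond the scatter)), and 4-fluoro-3-(methoxycarbonyl)phenyl in place of 3-fluorophenyl gives (a 2.9-fold lower number from compound 1 to compound 4 (0.46 log units; beyond the scatter)), while the earlier swaps there all stayed within it. Against 3,4-dimethoxyphenyl the new group gives only (a 1.7-fold lower number from compound 3 to compound 4 (0.23 log units; within the scatter)), a step still within the scatter. No evidence available here accounts for these steps.

Open, going by these compounds, is whether methoxycarbonyl itself matters, or whether a carboxylic acid or a primary amide in its place would give the same number.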